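The compounds below may be only part of what the source reports. "The series", "measured", "known", "first", "only" and "open" are said of these compounds alone.

Going by the values given here, compound 3 `CC1CCN(C2CCN(S(=O)(=O)c3ccc(Br)c(Cl)c3)CC2)CC1` is the only member of this small set to return a number in a functional assay on DLD-1 cells (Homo sapiens) for antiproliferative activity, read by CellTiter-Glo, with a stated time of 72 h (a lower number here means a stronger inhibitor, a higher number a weaker inhibitor), where compound 3 gives 12 nM. Compound 1 `CC1CCN(C2CCN(S(=O)(=O)c3cccc(C(F)(F)F)c3)CC2)CC1` reaches only a limit of > 5000 nM in this assay. Compound 2 `CC1CCN(C2CCN(S(=O)(=O)c3nccn3C)CC2)CC1` likewise stops at a limit of > 5000 nM in this assay. Among the compounds with values here, the single measured step, an at least 410-fold lower number from compound 2 to compound 3 (2.61 log units; beyond the scatter), is therefore the only guide to the weight of the aryl group on the sulfonyl sulfur, and it rests on (the limit of > 5000 nM in this assay, at which 2 of the 3 values shown sit), so its true size is unknown beyond that floor.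

Compound 4 `CC1CCN(C2CCN(S(=O)(=O)c3cccc(Br)c3)CC2)CC1` differs from compound 3 by 3-bromophenyl in place of 4-bromo-3-chlorophenyl on a sulfonyl sulfur. Within the data shown here, no measured step covers the loss of one halogen from the phenyl ring; compound 1, which carries a single substituent on that ring, sits at a limit, while compound 3 carries two and gives a number. On that basis a weakening step is expected, a 13-fold higher number from compound 3 to compound 4 (1.10 log units; beyond the scatter), though its size is uncertain. Compound 4 is expected to give about 150 nM in this assay, within a range from 30 nM to 2000 nM.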

Compound 4, half-maximal inhibitory concentration: 3.2 nM
Beside the measured number, compound 4's estimate is 47-fold (1.67 log units) above it, outside the stated range (below it).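

A second halogen on the phenyl ring proves unnecessary for activity in this assay, as 3-bromophenyl in place of 4-bromo-3-chlorophenyl on the sulfonyl sulfur gives a 3.8-fold lower number from compound 3 to compound 4 (0.57 log units; beyond the scatter). A single substituent on that ring can therefore suffice, but its identity matters: bromo in place of trifluoromethyl on an aromatic carbon gives an at least 1500-fold lower number from compound 1 to compound 4 (3.19 log units; beyond the scatter), and the change from the 1-methyl-1H-imidazol-2-yl group gives an at least 1500-fold lower number from compound 2 to compound 4 (3.19 log units; beyond the scatter). The true sizes of these last two steps cannot be read, and each gives only a floor: the limit of > 5000 nM in this assay, at which 2 of the 4 values shown sit.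

The compounds shown leave open whether 3-chlorophenyl, 3-iodophenyl or 3-methoxyphenyl on the sulfonyl sulfur would match compound 4. They also leave open how the number would respond to a change in the shared core, such as an added amine or carboxylic acid.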